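From Methyl Ester to Cyclohexane Acid on a Shared Core

The source may hold more compounds than are shown below. What is called first, only, known or untested is meant among the compounds shown, and "the series" means these compounds.

Measured so far:
Compound 1, `COC(=O)C(C)(C)NC(=O)c1cc(F)cc2cc(-c3ccc(Cl)cc3)oc12`, gives > 10000 nM.
Compound 2, `CN(C(=O)c1cc(F)cc2cc(-c3ccc(Cl)cc3)oc12)C(C)(C)C(=O)O`, gives 1970 nM.
Compound 3, `CC(C)(NC(=O)c1cccc2cc(-c3ccc(Cl)cc3)oc12)C(=O)O`, gives 1030 nM.

In an assay on isolated protein for inhibition of endoplasmic reticulum aminopeptidase 1 (Homo sapiens), with stated times of 15 min and 20 min (on this read-out lower numbers stand for stronger inhibition and higher numbers for weaker inhibition), the reading for compound 1 is a limit of the assay, not a number, so compound 1 sits at the limit of > 10000 nM in this assay, at which 1 of the 3 values shown sits. The compound still to be measured is compound 4, `O=C(NC1(C(=O)O)CCCCC1)c1cc(F)cc2cc(-c3ccc(Cl)cc3)oc12`, and it differs from compound 1 in one place: 1-carboxycyclohexyl in place of 1-(methoxycarbonyl)-1-methylethyl on an amide-type nitrogen. Among the measured compounds shown here, the one measured step that bears on this is an at least 5.0-fold lower number from compound 1 to compound 2 (0.70 log units; beyond the scatter), where the methyl ester likewise became a free acid. Compound 3, which carries a free acid next to an amide hydrogen, gives 1030 nM. Compound 4 is therefore expected to show a step of an at least 10-fold lower number from compound 1 to compound 4 (1.00 log units; beyond the scatter), with an estimated value of 1000 nM, likely between 300 nM and 4000 nM.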

Compound 4, half-maximal inhibitory concentration: 34 nM
Compound 4: middle estimate off by 29-fold (1.47 log units), on the high side, outside the stated range (below it).
By their numbers in this assay, from the lowest: compound 4; then compounds 3 and 2 (each within the scatter of the next). At a limit, above all of these: compound 1.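

Among the compounds shown here, replacing 1-(methoxycarbonyl)-1-methylethyl with 1-carboxycyclohexyl on this amide-type nitrogen gives a large gain (an at least 290-fold lower number from compound 1 to compound 4 (2.46 log units; beyond the scatter)), so a change in this one place can carry the shared core far beyond what the earlier compounds showed. The size of that step is only a minimum, since compound 1 stands at a limit of the assay and not at a number: (the limit of > 10000 nM in this assay, at which 1 of the 4 values shown sits).

On these data alone, this one change swaps the ester for an acid and the two methyl groups for a ring together, so the share of each stays open. As far as these compounds go, whether 1-carboxycyclopentyl, or an amine in place of the carboxylic acid, would serve as well also stays open.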